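Swapping the Group on the Carbonyl: Toward Compound 4

The source may hold more compounds than are shown below. What is called first, only, known or untested is meant among the compounds shown, and "the series" means these compounds.

Measured compounds in a functional assay (trachea) with Rattus norvegicus as the target; a lower number here means a less potent compound, a higher number a more potent compound, by a factor of ten per unit of this negative logarithm:
- compound 1 `CCC(=O)c1ccc2c(c1)C(n1ccccc1=O)=CC(C)(C)O2`: 5.85
- compound 2 `CC1(C)C=C(n2ccccc2=O)c2cc(C(=O)c3ccccc3)ccc2O1`: 6.21
- compound 3 `CC1(C)C=C(n2ccccc2=O)c2cc(C(=O)c3ccccc3[N+](=O)[O-])ccc2O1`: 5.64

All three share one core and differ only in the group attached to the carbonyl carbon. Compound 3 has the lowest of the three numbers; compound 1 is nearest to it, and the gap between them is within the scatter, while compound 2 stands clearly higher, as the step of a number 0.57 log units lower from compound 2 to compound 3 (beyond the scatter) shows.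

Compound 4 `CC1(C)C=C(n2ccccc2=O)c2cc(C=O)ccc2O1` has not yet been measured. Its change from compound 3 is hydrogen in place of 2-nitrophenyl on a carbonyl carbon. Going by the values given here, no measured step removes the group on the carbonyl carbon altogether, so the comparison is indirect. The two steps that vary that group, a number 0.36 log units higher from compound 1 to compound 2 (beyond the scatter) and a number 0.21 log units lower from compound 1 to compound 3 (within the scatter), were modest or within the scatter, which suggests the group here moves the number only moderately. Compound 4 is therefore expected to land close to compound 1 and compound 3, with an estimated step of a number 0.06 log units higher from compound 3 to compound 4 (within the scatter) that is unlikely to exceed the scatter. The estimate for compound 4 in this assay is 5.7, in the range 5.1 to 6.3.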

Compound 4, logarithm of the reciprocal of the active concentration, log(1/C): 6.14
Compound 4: middle estimate off by 0.44 log units, on the low side; the measured number falls inside the stated range.
By their numbers in this assay, from the lowest: compounds 3, 1, 4 and 2 (each within the scatter of the next, the first and the last beyond it).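

In this assay the carbonyl carbon turns out to need no larger group: with only hydrogen there, the steps, a number 0.07 log units lower from compound 2 to compound 4 (within the scatter) and a number 0.29 log units higher from compound 1 to compound 4 (within the scatter), leave compound 4 indistinguishable from compound 1 and compound 2. The 2-nitrophenyl group is the one that separates from hydrogen, with a number 0.50 log units higher from compound 3 to compound 4 (beyond the scatter), so among these compounds a ring on the carbonyl carbon does not by itself go with a lower number, as phenyl in compound 2 shows. Nothing available links this pattern to a measured property of the groups.

On these data alone, whether an amine or a methoxy group on the carbonyl carbon would stay at this level remains open. So does whether chlorine on the phenyl ring of compound 2 would lower the number as nitro does.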